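Cytotoxicity limits on the way to compound 3

This account rests on a few compounds, and the source may have more. Where it says the series, first, only, none or still open, it means among the compounds named here.

- compound 1 `O=c1c(O)cccn1Cc1ccccc1`, a limit: > 10 ug/mL
- compound 2 `N#Cc1cccc(-c2ccc(Cn3cccc(O)c3=S)cc2)c1`, a limit: > 10 ug/mL

In an ADME assay on THP-1 cells (Homo sapiens) for cytotoxicity, read by resazurin assay, with a stated time of 48 h (a higher number here means a weaker inhibitor, a lower number a stronger inhibitor), compound 1 gives > 10 ug/mL, which is a limit and not a number. Compound 2 also gives a limit, > 10 ug/mL. Going by the values given here, the series so far shows (the limit of > 10 ug/mL in this assay, at which 2 of the 2 values shown sit). Among the compounds with values here, no measured step is available, and compound 1 can be placed only on one side of that limit.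

The next compound is compound 3 `Cc1cccc(-c2ccc(Cn3cccc(O)c3=O)cc2)c1`. Relative to compound 1, a hydrogen atom leaves and 3-methylphenyl enters on an aromatic carbon, para to a group of 9 heavy atoms (3-methylphenyl in place of hydrogen on an aromatic carbon).

In this assay no change beyond the scatter is expected, and the estimated step is a number no higher from compound 1 to compound 3 (the limit leaves the size open). This expectation rests on the limit of compound 2, > 10 ug/mL, and a further limit is the most likely report. Compound 3 is estimated at 10 ug/mL, with an expected range from 4 ug/mL to 20 ug/mL.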

Compound 3, half-maximal inhibitory concentration: > 10 ug/mL
Compound 3 gave a limit, no number; the forecaster's own chance of this, stated with the estimate: 70%; the middle value lies on the limit itself.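

In this assay no step can be read between compound 1 and compound 3, because both give only a limit and not a number, and the series sits at one shared limit: the limit of > 10 ug/mL in this assay, at which 3 of the 3 values shown sit.

The compounds shown leave open whether 3-methylphenyl in place of hydrogen on an aromatic carbon changes cytotoxicity at all, and at what concentration any of them would reach half-maximal inhibition.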